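Hydroxy replacements on the shared core: solubility notes

This account rests on a few compounds, and the source may have more. Where it says the series, first, only, none or still open, it means among the compounds named here.

Measured so far:
compound 1, `O=C1O[C@@H](CO)CN1c1ccc(-n2cc(-c3ccccn3)cn2)c(F)c1` — 56400 nM
compound 2, `O=C1CSC(=O)N1C[C@H]1CN(c2ccc(-n3cc(-c4ccccn4)cn3)c(F)c2)C(=O)O1` — 26900 nM

In a physicochemical assay for solubility, read by HPLC, with a stated time of 24 h (a higher number here means a more soluble compound, a lower number a less soluble compound), compound 1 gives 56400 nM, the highest of the two numbers; its nearest neighbour, compound 2, gives 26900 nM. For the measured compounds named here, the one measured step, a 2.1-fold lower number from compound 1 to compound 2 (0.32 log units; beyond the scatter), swaps the hydroxy on a saturated chain carbon bound to a saturated ring carbon for a larger group.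

Compound 3, `O=C1O[C@@H](CNC(=O)C(F)(F)F)CN1c1ccc(-n2cc(-c3ccccn3)cn2)c(F)c1`, alters compound 1 at the same position: ((trifluoromethyl)carbonyl)amino in place of hydroxy on a saturated chain carbon bound to a saturated ring carbon. Going by the values given here, the step from compound 1 to compound 2 is the only one that bears on it, since it is the only measured change at that hydroxy; there the number fell modestly. A change of comparable kind is expected here, so the estimated step of a 2.3-fold lower number from compound 1 to compound 3 (0.35 log units; beyond the scatter) should be downward and beyond the scatter but not large. For compound 3 the expected value is 25000 nM, with a range of 10000 nM to 60000 nM.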

Compound 3, solubility: 114000 nM
For compound 3 the middle estimate is 4.6-fold (0.66 log units) below the measured one, outside the stated range (above it).
By their numbers in this assay, from the lowest: compound 2; then compound 1; then compound 3.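

In this assay the position on a saturated chain carbon bound to a saturated ring carbon now moves in both directions: ((trifluoromethyl)carbonyl)amino in place of hydroxy gives a 2.0-fold higher number from compound 1 to compound 3 (0.31 log units; beyond the scatter) and so runs opposite to the earlier step at this position. The two replacements also stand apart, with a 4.2-fold higher number from compound 2 to compound 3 (0.63 log units; beyond the scatter) between them, so among these three compounds, replacing hydroxy with a larger group does not by itself set the direction of the change. Nothing available here explains why the two replacements part in this way.

Going by these compounds, it remains open where a simple amine or a carboxylic acid on the same chain carbon would fall relative to these numbers. An acetylamino group would show whether the trifluoromethyl part of the new group matters to the higher number.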